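The source may report more compounds than this note shows. Statements on the series, on what has been measured and on what is new or still open speak of the compounds shown alone.

Measured compounds:
compound 1 `CCCCCCCCCCCCn1nnc(C(C(=O)Nc2ccc(F)cc2F)c2ccccc2)n1` — in an assay on isolated protein for inhibition of sterol O-acyltransferase 1 (Mus musculus), tested at 0.1 uM (a lower number here means less inhibition, a higher number more inhibition at the concentration tested (going by the name of the read-out)), compound 1 gives 1%
compound 2 `CCCCCCCCCCCCn1nnc(C(C(=O)Nc2ncccc2C)c2ccccc2)n1` — in this assay compound 2 gives 4%

Both numbers sit near the bottom of the scale, and compound 2 holds the higher of the two only by a number 3 percentage points higher from compound 1 to compound 2 (within the scatter), which is within the scatter, so the two compounds cannot be told apart on these values. Compound 3 `CCCCCCCCCCCCn1nnc(C(C(=O)Nc2c(OC)ncnc2OC)c2ccccc2)n1` keeps the whole shared core and differs from compound 2 in one place: a group of 10 heavy atoms (6 carbon, 2 nitrogen, 2 oxygen; one six-membered aromatic ring with 2 hetero atoms) in place of a group of 7 heavy atoms (6 carbon, 1 nitrogen; one six-membered aromatic ring with 1 hetero atom), on an amide-type nitrogen. Among the compounds with values here, the only measured step, from compound 1 to compound 2, also exchanged the ring on the amide-type nitrogen and moved the number by a number 3 percentage points higher from compound 1 to compound 2 (within the scatter), without leaving the scatter. Within the data shown here, no measured pair shows a ring of the kind that enters here, so no step beyond the scatter can be expected from this change alone. Compound 3 is therefore expected to give about 3% in this assay, within -8% to 15%, meaning an expected step of a number 1 percentage points lower from compound 2 to compound 3 (within the scatter).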

Compound 3, a percentage reported as inhibition, at one concentration (the size of the read-out at that concentration, not a potency): 39%
The estimate for compound 3 lay 36 percentage points below the measured number, and the stated range ends below it.
By their numbers in this assay, from the lowest: compounds 1 and 2 (each within the scatter of the next); then compound 3.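

This position on the amide-type nitrogen is not indifferent to what it carries, although the exchange between the first two rings suggested that it might be. In this assay, the group of 10 heavy atoms, with its six-membered aromatic ring with 2 hetero atoms, gives a large rise against 3-methylpyridin-2-yl, a number 35 percentage points higher from compound 2 to compound 3 (beyond the scatter), and a similar rise against 2,4-difluorophenyl, a number 38 percentage points higher from compound 1 to compound 3 (beyond the scatter), so the gain holds against both earlier groups. Nothing available explains what in the entering group produces this gain.

The entering group differs from both earlier groups in its ring and in its 2 oxygen atoms together, so the compounds shown do not separate these two changes. On these data alone, it also remains open whether an amine or a chlorine in place of the oxygen-bearing groups would keep the gain.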